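Bromo for chloro, carried from one core to another

A few compounds are considered here, and "the series" means these few. Any claim that something is new, unique, unknown or untested is made for them only; others in the source may bear on it.

Measured so far in a functional assay on HepG2 cells (Homo sapiens) for antiproliferative activity, read by sulforhodamine B assay, with a stated time of 48 h; a higher number here means a weaker inhibitor, a lower number a stronger inhibitor:

compound 1 `COc1cccc(C2=CC(c3ccc(Cl)cc3)NC(=S)N2)c1` gives 54 nM
compound 2 `COc1cccc(C2=CC(c3ccc(Br)cc3)NC(=S)N2)c1` gives 34 nM
compound 3 `COc1ccc(C(=O)C2OC2c2ccc(Cl)cc2)cc1` gives 15 nM

Compound 1 and compound 2 share one core and differ only by bromo in place of chloro on an aromatic carbon. That change made a 1.6-fold lower number from compound 1 to compound 2 (0.20 log units; within the scatter), so within this pair it is not distinguishable from repeat scatter.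

Compound 3 stands on a different core; the difference between the two cores is not broken down here. Its number is the lowest of the three, and its gaps to compound 2 and to compound 1 are both beyond the scatter.

Compound 4 `COc1ccc(C(=O)C2OC2c2ccc(Br)cc2)cc1` is the partner of compound 3 carrying (bromo in place of chloro on an aromatic carbon). The place is described in the same words as for compound 1 to compound 2, so this is the same change set on the core of compound 3. For the measured compounds named here, with only one earlier instance, the expectation rests on that step: from compound 3 to compound 4 a step of about a 1.4-fold lower number from compound 3 to compound 4 (0.13 log units; within the scatter) is expected, matching a 1.6-fold lower number from compound 1 to compound 2 (0.20 log units; within the scatter) in size, which means a number within the scatter of compound 3. Compound 4 is estimated at 11 nM, with a range of 5 nM to 25 nM.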

Compound 4, half-maximal inhibitory concentration: 30 nM
For compound 4 the middle estimate is 2.7-fold (0.44 log units) below the measured one; the whole stated range lies below it.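

In this assay, bromo in place of chloro on an aromatic carbon gives a 2.0-fold higher number from compound 3 to compound 4 (0.30 log units; within the scatter), so this step alone cannot be told from repeat scatter. Set beside the earlier step, the same change does not carry over as a single value: the same change on two cores in this assay, a 1.6-fold lower number (0.20 log units; within the scatter) from compound 1 to compound 2 and a 2.0-fold higher number (0.30 log units; within the scatter) from compound 3 to compound 4, 3.2-fold (0.50 log units) apart, beyond the scatter of two such steps. This shows that the step on the core of compound 1 did not fix the step on the core of compound 3, but it does not show what in the two cores accounts for the gap, and two pairs support no general rule for this change across the series.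

The compounds shown leave open how fluoro or an amine on that aromatic carbon would read on either core. They also leave open whether the two cores would part in the same way for those groups, or whether the gap is confined to the exchange of chloro and bromo.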